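From 3-methylphenyl to 4-methylpyridin-3-yl in compound 2

The source may hold more compounds than are shown below. What is called first, only, known or untested is meant among the compounds shown, and "the series" means these compounds.

Values in a physicochemical assay for lipophilicity, read by HPLC, at pH 7.5 (on this read-out lower numbers stand for lower lipophilicity and higher numbers for higher lipophilicity), follow
compound 1 `CCOc1ccccc1-c1ccc(-c2nc3cnccc3c(NC(C)C(=O)O)c2C#N)cc1` gives 2.1
compound 2 `CC[C@@H](Nc1c(C#N)c(-c2ccc(-c3cccc(C)c3)cc2)nc2cnccc12)C(N)=O` gives 3
compound 3 `CCOc1ccccc1-c1ccc(-c2nc3cnccc3c(N)c2C#N)cc1` gives 3

Compound 2 stands level with compound 3, the two sharing the highest of the three values, while compound 1 lies clearly lower. Compound 4 `CC[C@@H](Nc1c(C#N)c(-c2ccc(-c3cnccc3C)cc2)nc2cnccc12)C(N)=O` carries 4-methylpyridin-3-yl in place of 3-methylphenyl on an aromatic carbon in the same setting. Going by the values given here, the only measured step is a number 0.90 log units higher from compound 1 to compound 3 (beyond the scatter) and it concerns hydrogen in place of 1-carboxyethyl on a nitrogen on an aromatic ring. Among the compounds with values here, it offers a scale but no precedent, since no measured pair makes this ring exchange. A modest step down, beyond the scatter, is expected in this assay for this change. The expected step is a number 0.80 log units lower from compound 2 to compound 4 (beyond the scatter) by this estimate. Compound 4 is estimated at 2.2 with a range from 1.7 to 2.7 expected.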

Compound 4, distribution coefficient: 2
Estimate against measurement, compound 4: 0.20 log units above; the range from low to high includes it.
By their numbers in this assay, from the lowest: compounds 4 and 1 (each within the scatter of the next); then compounds 2 and 3 (each within the scatter of the next).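

In this assay, putting 4-methylpyridin-3-yl in place of 3-methylphenyl, on an aromatic carbon para to a large group, gives a number 1.00 log units lower from compound 2 to compound 4 (beyond the scatter). Going by these compounds alone, this is the first measured step at this position, and the exchange keeps the heavy-atom count at 7 while swapping one ring carbon for nitrogen. Nothing measured here bears on what lies behind the step. On these data alone, it remains open whether an unmethylated pyridin-3-yl, or an aminophenyl or a carboxyphenyl group, would move the number as far at this position.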